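Replacing the Urea Aryl of Compound 1 with a Benzamide

A few compounds are considered here, and "the series" means these few. Any claim that something is new, unique, unknown or untested is made for them only; others in the source may bear on it.

Compound 1 `COc1cc(-c2nn(-c3cccc(NC(=O)Nc4ccc(Cl)c(Cl)c4)c3)cc2-c2ccncc2)ccc1Cl`: 4490 nM
Compound 2 `O=C(Nc1cccc(-n2cc(-c3ccncc3)c(-c3ccc(Cl)c(O)c3)n2)c1)Nc1ccc(Cl)c(Cl)c1`: 29200 nM
Compound 3 `O=C(Nc1cccc(-n2cc(-c3ccncc3)c(-c3ccc(Cl)c(O)c3)n2)c1)Nc1cc(C(F)(F)F)cc(C(F)(F)F)c1`: 8460 nM

In a functional assay on UACC-62 cells (Homo sapiens) for inhibition, read by sulforhodamine B assay, with a stated time of 48 h (a lower number here means that less compound is tolerated, a higher number that more compound is tolerated), compound 1 gives the lowest of the three numbers; compound 3 sits within the scatter of it, while compound 2 stands apart by a 6.5-fold higher number from compound 1 to compound 2 (0.81 log units; beyond the scatter). Compound 4 `COc1cc(-c2nn(-c3cccc(NC(=O)c4ccccc4)c3)cc2-c2ccncc2)ccc1Cl` is not yet measured. It differs from compound 1 by phenyl in place of (3,4-dichlorophenyl)amino on a carbonyl carbon. For the measured compounds named here, no measured step touches this part of the molecule directly. Compound 2 and compound 3 differ in the same region, and their two values in this assay differ widely, which shows that this part of the structure matters. Since the group that leaves carries the only hydrogen-bond donor of the urea, compound 4 is expected to tolerate more, a 2.7-fold higher number from compound 1 to compound 4 (0.43 log units; beyond the scatter). The estimate for compound 4 is 12000 nM, with a range from 4000 nM to 40000 nM.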

Compound 4, concentration lethal to 50% of the cells: > 100000 nM
Compound 4 gave a limit, no number (the forecaster's own chance of this, stated with the estimate: 10%); at least 8.3-fold (0.92 log units) between middle value and limit.
By their numbers in this assay, from the lowest: compounds 1 and 3 (each within the scatter of the next); then compound 2. At a limit, above all of these: compound 4.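

Phenyl in place of (3,4-dichlorophenyl)amino on a carbonyl carbon gives an at least 22-fold higher number from compound 1 to compound 4 (1.34 log units; beyond the scatter), a large step in this assay. Compounds 1, 2 and 3 all keep the urea, so they gave no reading of a change that removes it. Compound 4 stands at a limit, not a number: the limit of > 100000 nM in this assay, at which 1 of the 4 values shown sits.

This one change takes away the amide-type nitrogen and the chlorines together, and the compounds shown do not separate the two. From the compounds shown here alone, it stays open whether phenylamino or 3,4-dichlorophenyl on the same carbonyl carbon would stay close to compound 1 or move towards compound 4.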